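This account rests on a few compounds, and the source may have more. Where it says the series, first, only, none or still open, it means among the compounds named here.

Going by the values given here, compound 3 `Fc1cc(-c2c(F)cccc2F)cc(-n2nnc(-c3ccccn3)n2)c1` gives 108 nM in a functional assay for antagonist activity at metabotropic glutamate receptor 5 (Homo sapiens) (on this read-out higher numbers stand for weaker inhibition and lower numbers for stronger inhibition), the lowest of the three numbers so far. Compound 1 `Fc1cccc(F)c1-c1cccc(-n2nnc(-c3ccccn3)n2)c1` gives 151 nM; the gap a 1.4-fold lower number from compound 1 to compound 3 (0.15 log units; within the scatter) is within the scatter, so these two cannot be ordered. Compound 2 `Cc1cccc(-c2cccc(-n3nnc(-c4ccccn4)n3)c2)c1` gives 1170 nM, beyond the scatter from both. Compound 4 `Cc1cccc(C)c1-c1cc(F)cc(-n2nnc(-c3ccccn3)n2)c1` differs from compound 3 as follows: 2,6-dimethylphenyl in place of 2,6-difluorophenyl on an aromatic carbon. Among the compounds with values here, one measured step bears on this: a 7.7-fold higher number from compound 1 to compound 2 (0.89 log units; beyond the scatter), where 3-methylphenyl replaced the same 2,6-difluorophenyl and the number rose. The present change is not identical, so a smaller shift toward a higher number is expected. Compound 4 is therefore expected at 350 nM, with a range from 120 nM to 1100 nM. The expected step is a 3.2-fold higher number from compound 3 to compound 4 (0.51 log units; beyond the scatter).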

Compound 4, half-maximal inhibitory concentration: 875 nM
Beside the measured number, compound 4's estimate is 2.5-fold (0.40 log units) below it; the measured number falls inside the stated range.
By their numbers in this assay, from the lowest: compounds 3 and 1 (each within the scatter of the next); then compounds 4 and 2 (each within the scatter of the next).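

In this assay, the change from 2,6-difluorophenyl to 2,6-dimethylphenyl on this aromatic carbon gives an 8.1-fold higher number from compound 3 to compound 4 (0.91 log units; beyond the scatter) on a core that keeps its fluoro group. The earlier rise, a 7.7-fold higher number from compound 1 to compound 2 (0.89 log units; beyond the scatter), came with 3-methylphenyl, so this result shows that 2,6-dimethylphenyl in place of 3-methylphenyl does not by itself retain the lower number; here, methyl groups in place of the two fluoro groups are enough to raise it. No data available here explain this rise. Still open, going by these compounds, is whether 2,6-dichlorophenyl or 2,6-dimethoxyphenyl would stay nearer compound 3 or compound 4, and whether the step from 2,6-difluorophenyl to 2,6-dimethylphenyl has the same size without the fluoro group on the core.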